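Swapping 4-fluorobenzyl for 4-methylphenyl on a sulfur

The compounds below may be only part of what the source reports. "The series", "measured", "known", "first", "only" and "open" are said of these compounds alone.

In a functional assay on DU-145 cells (Homo sapiens) for inhibition, read by trypan blue exclusion, with a stated time of 96 h (on this read-out higher numbers stand for weaker inhibition of growth and lower numbers for stronger inhibition of growth), compound 1 `CCOc1ccc(/C=C(/SCc2ccc(F)cc2)C(=O)c2ccc(Br)cc2)cc1OC` gives 50000 nM and holds the higher of the two exact numbers available. Compound 3 `COc1ccc(/C=C(\C(=O)c2ccc(Cl)cc2)S(=O)(=O)c2ccc(Br)cc2)cc1O` shows 10000 nM and so stronger growth inhibition than compound 1, a gap beyond the usual scatter. Compound 2 `Cc1ccc(S/C(=C/c2ccc(N(C)C)cc2)C(=O)c2ccc(Cl)cc2)cc1` carries 4-methylphenyl on a sulfur and reads > 100000 nM as a limit of the assay, not a number.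

Compound 4 `CCOc1ccc(/C=C(/Sc2ccc(C)cc2)C(=O)c2ccc(Br)cc2)cc1OC` differs from compound 1 in one place, with 4-methylphenyl in place of 4-fluorobenzyl on a sulfur. Within the data shown here, no measured pair shows this change alone, so any expectation is loose. Compound 2 shares the entering group and sits at > 100000 nM (again a limit), but it differs elsewhere too, so only a slight lean toward weaker inhibition is expected. In this assay no step beyond the scatter is expected, and the estimated step of a 1.2-fold higher number from compound 1 to compound 4 (0.08 log units; within the scatter) stays small. Compound 4 is estimated to read 60000 nM with an expected range from 20000 nM to 100000 nM on this measurement.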

Compound 4, concentration for 50% growth inhibition: 50000 nM
For compound 4 the middle estimate is 1.2-fold (0.08 log units) above the measured one; the range from low to high includes it.
By their numbers in this assay, from the lowest: compound 3; then compounds 1 and 4 (each within the scatter of the next). At a limit, above all of these: compound 2.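

Among these compounds, replacing 4-fluorobenzyl with 4-methylphenyl on this sulfur gives no change at the digits printed from compound 1 to compound 4 (within the scatter) in this assay, the first comparison here in which only this group differs. Both groups carry one six-membered aromatic ring of carbon only, yet the fluorine is lost and the attachment to the sulfur differs. Within this one pair, this assay does not separate the two groups.

From the compounds shown here alone, it remains open whether the same holds with a group of another kind on this sulfur, such as a longer alkyl chain or a ring bearing a carboxylic acid, or whether the result carries over to other cores. The top of the scale also restricts what can be read, since compound 2 stands at a limit and not at a number: the limit of > 100000 nM in this assay, at which 1 of the 4 values shown sits.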